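Growing the Allyl Arm of a Weak Breast-Cancer Cell Inhibitor

A few compounds are considered here, and "the series" means these few. Any claim that something is new, unique, unknown or untested is made for them only; others in the source may bear on it.

Compound 1, `COc1ccc(C(c2ccc(OC(C)CN(C)C)cc2)c2cccc3ccccc23)c(OC)c1OC`, in a functional assay on MCF7 cells (Homo sapiens) for inhibition, read by sulforhodamine B assay, with a stated time of 48 h (a lower number here means a stronger inhibitor, a higher number a weaker inhibitor), gives 13100 nM. Compound 2, `C=CCC(O)(c1ccc(OC)c(OC)c1OC)c1cccc2ccccc12`, in this assay gives only a limit, > 20000 nM. Compound 3, `COc1cc(COC(c2ccc(OC)c(OC)c2OC)c2cccc3ccccc23)cc(OC)c1`, in this assay likewise gives only a limit, > 20000 nM.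

Compound 2 thus stands at the limit of > 20000 nM in this assay, at which 2 of the 3 values shown sit; its result is a limit and not a number. Compound 4, `COc1ccc(C(O)(C/C=C\c2ccccc2)c2cccc3ccccc23)c(OC)c1OC`, carries 2-phenylethenyl in place of vinyl on a saturated chain carbon, two bonds along the chain from two aromatic carbons and an oxygen on a saturated carbon. Among the compounds with values here, no measured pair differs in just this way, so the size of this step is unknown. Since compound 2 sits at a limit, a change beyond the scatter could show only as a gain, and none is expected; the step of an at least 1.1-fold lower number from compound 2 to compound 4 (0.04 log units; that floor lies within the scatter) is expected to be small. Compound 4 is estimated at 18000 nM, between 6000 nM and 40000 nM, with a fair chance that again only a limit is reported.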

Compound 4, half-maximal inhibitory concentration: 10200 nM
The estimate for compound 4 lay 1.8-fold (0.25 log units) above the measured number; the range from low to high includes it.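

Putting 3-phenylprop-2-en-1-yl in place of allyl at this position gives an at least 1.9-fold lower number from compound 2 to compound 4 (0.29 log units; that floor lies within the scatter). The larger arm with its added aromatic ring therefore still leaves a measurable number in this assay, where the allyl compound gave none. The true size of the step stays unknown, because one end of it is only a limit: the limit of > 20000 nM in this assay, at which 2 of the 4 values shown sit.

On these data alone, whether an amine or a carboxylic acid on this arm would lower the number remains open. So does the result for a longer saturated chain ending in a phenyl ring.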